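Removing the amino group: from compound 2 to compound 3

The compounds below may be only part of what the source reports. "The series", "measured", "known", "first", "only" and "open" are said of these compounds alone.

Among the measured compounds shown here, compound 1 `ClCc1cccc(Cn2cnc3c(Cl)nc(Cl)nc32)c1` and compound 2 `Nc1nc(Cl)c2ncn(Cc3ccccc3CCl)c2n1` are the two measured members; compound 3 `ClCc1ccccc1Cn1cnc2c(Cl)ncnc21` is still to be measured. In a functional assay on PC-3 cells (Homo sapiens) for cytotoxicity, read by sulforhodamine B assay, with a stated time of 48 h (a lower number here means that less compound is tolerated, a higher number that more compound is tolerated), compound 1 gives 55000 nM. For compound 2 only a limit is recorded in this assay, namely > 100000 nM (the limit of > 100000 nM in this assay, at which 1 of the 2 values shown sits). Compound 2 thus stands where no number, only a limit, is known. Compound 3 differs from compound 2 by hydrogen in place of amino on an aromatic carbon, on an aromatic carbon of a six-membered aromatic ring with 2 nitrogen, between two ring nitrogen atoms. For the measured compounds named here, no measured step exists; a small move toward a measurable number, close to the scatter, is expected, an at least 1.2-fold lower number from compound 2 to compound 3 (0.09 log units; that floor lies within the scatter). Compound 3 is estimated at 80000 nM, range 30000 nM to 250000 nM.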

Compound 3, concentration lethal to 50% of the cells: 53700 nM
Compound 3: middle estimate off by 1.5-fold (0.17 log units), on the high side; low and high end bracket the measured number.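

In this assay hydrogen in place of amino on an aromatic carbon, between two ring nitrogen atoms, gives an at least 1.8-fold lower number from compound 2 to compound 3 (0.27 log units; that floor lies within the scatter) as the first step read at this position. The change gives compound 3 a number where compound 2 has none. From the compounds shown here alone, compound 2 stands only at a limit, so the true size of the step stays unknown: the limit of > 100000 nM in this assay, at which 1 of the 3 values shown sits.

Going by these compounds, how a methylamino or hydroxyl group on the same aromatic carbon would read remains open. Also open, on these data alone, is whether the step holds with a morpholine in place of the chloro group.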